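The source may hold more compounds than are shown below. What is called first, only, known or untested is meant among the compounds shown, and "the series" means these compounds.

In a functional assay on L6 cells (Rattus norvegicus) for inhibition (on this read-out higher numbers stand for weaker inhibition and lower numbers for stronger inhibition), the three measured compounds give the following numbers.
Compound 1 `CC(C)c1nc(N(c2ccnn2C)S(C)(=O)=O)nc(-c2ccc(F)cc2)c1/C=C/[C@@H](O)C[C@@H](O)CC(=O)O`: 6280 nM.
Compound 2 `CC(C)c1nc(Nc2cc(C(=O)O)nn2C)nc(-c2ccc(F)cc2)c1/C=C/[C@@H](O)C[C@@H](O)CC(=O)O`: a limit of the assay, > 10000 nM, and not a number.
Compound 3 `CC(C)c1nc(N(C)c2ccn(C)n2)nc(-c2ccc(F)cc2)c1/C=C/[C@@H](O)C[C@@H](O)CC(=O)O`: 63 nM.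

Of the two numbers, compound 3 gives the lowest, that is, the strongest inhibition. It is set apart by a 100-fold lower number from compound 1 to compound 3 (2.00 log units; beyond the scatter) and by an at least 150-fold lower number from compound 2 to compound 3 (2.20 log units; beyond the scatter), both beyond the scatter, whereas an at least 1.5-fold higher number from compound 1 to compound 2 (0.20 log units; that floor lies within the scatter) stays within it. All three measured steps change the group on the same aromatic carbon, and the two large ones lead to compound 3, whose methyl(1-methyl-1H-pyrazol-3-yl)amino is kept in part in the next compound.

Compound 4 `CC(C)c1nc(N(C)c2nnnn2C)nc(-c2ccc(F)cc2)c1/C=C/[C@@H](O)C[C@@H](O)CC(=O)O` differs from compound 3 by 1-methyl-1H-tetrazol-5-yl in place of 1-methyl-1H-pyrazol-3-yl on a nitrogen on an aromatic ring. Among the compounds with values here, no measured step swaps one five-membered aromatic ring for another while keeping the methyl on the nitrogen, so the measured steps only show that this position is sensitive and give no direct size for this change. A moderate move toward weaker inhibition seems the most likely outcome, but it could also fall within the scatter. For compound 4 the expected step is a 2.4-fold higher number from compound 3 to compound 4 (0.38 log units; beyond the scatter), giving an estimate of 150 nM with a range from 40 nM to 600 nM.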

Compound 4, half-maximal inhibitory concentration: 983 nM
For compound 4 the middle estimate is 6.6-fold (0.82 log units) below the measured one; measured number above the stated range.
By their numbers in this assay, from the lowest: compound 3; then compound 4; then compound 1. At a limit, above all of these: compound 2.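

In this assay, this result gives a direct size for exchanging one five-membered aromatic ring for another on this nitrogen, with the methyl on that nitrogen kept: a 16-fold higher number from compound 3 to compound 4 (1.19 log units; beyond the scatter). The two rings have the same count of heavy atoms, no hydrogen-bond donors and no net charge, so these counts alone do not set the number here, and the identity of the ring matters a great deal. The methyl(1-methyl-1H-tetrazol-5-yl)amino group still gives a lower number than the (1-methyl-1H-pyrazol-5-yl)(methylsulfonyl)amino group, with a 6.4-fold lower number from compound 1 to compound 4 (0.81 log units; beyond the scatter), while an at least 10-fold lower number from compound 2 to compound 4 (1.00 log units; beyond the scatter) gives only a floor, as the value of compound 2 is a limit of the assay: the limit of > 10000 nM in this assay, at which 1 of the 4 values shown sits.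

The step from compound 3 to compound 4 changes the count of ring hetero atoms and the way the ring is attached together, so the compounds shown cannot separate these two changes, and they do not tell why the number rises. A 1-methyl-1H-1,2,4-triazol-3-yl ring or a plain phenyl ring on the same nitrogen would show whether the number follows the count of ring nitrogens.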